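Trifluoromethoxy in place of trifluoromethyl: expecting compound 4

The compounds below may be only part of what the source reports. "The series", "measured", "known", "first", "only" and "open" are said of these compounds alone.

In a functional assay on Gurav cells (Homo sapiens) for inhibition, read by sulforhodamine B assay (a higher number here means a weaker inhibitor of growth, a lower number a stronger inhibitor of growth), three compounds have been measured so far. Compound 2 (`Oc1cccc2[nH]c(-c3ccc(-c4ccc(-c5ccccc5)cc4)cc3)nc12`) gives 1110 nM, and compound 1 (`FC(F)(F)Oc1ccc(-c2ccc(-c3ccc(-c4nc5ccccc5[nH]4)cc3)cc2)cc1`) gives 100000 nM. Among the compounds with values here, compound 3 (`Oc1cccc2[nH]c(-c3ccc(-c4ccc(-c5ccc(C(F)(F)F)cc5)cc4)cc3)nc12`) gives 3190 nM, the second highest of the three numbers and the one nearest to compound 2.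

Compound 4 (`Oc1cccc2[nH]c(-c3ccc(-c4ccc(-c5ccc(OC(F)(F)F)cc5)cc4)cc3)nc12`) has trifluoromethoxy in place of trifluoromethyl on an aromatic carbon, para to a large group: trifluoromethoxy in place of trifluoromethyl on an aromatic carbon. Within the data shown here, only one measured step bears on this place, the modest 2.9-fold higher number from compound 2 to compound 3 (0.46 log units; beyond the scatter), in which trifluoromethyl took the place of hydrogen. Among the measured compounds shown here, that step starts from hydrogen, and no measured step shows the exchange of trifluoromethyl for trifluoromethoxy itself. A step of that modest size in either direction cannot be ruled out, but no step beyond the scatter is expected in this assay. The expected change is a 1.1-fold lower number from compound 3 to compound 4 (0.03 log units; within the scatter). Compound 4 is estimated at 3000 nM, with an expected range of 1200 nM to 8000 nM.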

Compound 4, concentration for 50% growth inhibition: 3600 nM
Compound 4: the middle estimate sits 1.2-fold (0.08 log units) below what was measured; low and high end bracket the measured number.
By their numbers in this assay, from the lowest: compound 2; then compounds 3 and 4 (each within the scatter of the next); then compound 1.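

In this assay, the direct exchange of trifluoromethyl for trifluoromethoxy at this position gives a 1.1-fold higher number from compound 3 to compound 4 (0.05 log units; within the scatter), so the two groups are not told apart here. Set against hydrogen, trifluoromethoxy gives a 3.2-fold higher number from compound 2 to compound 4 (0.51 log units; beyond the scatter), which makes it the second group at this position, after trifluoromethyl, to give a modestly higher number than hydrogen. With trifluoromethoxy held in place, hydroxy on the shared core accounts for a 28-fold lower number from compound 1 to compound 4 (1.44 log units; beyond the scatter), a far larger step than any seen at this position.

No measurement shown explains why these steps have the sizes they do. As far as these compounds go, it remains open whether an amine or a carboxylic acid at this position would give a number near those of the two fluorinated groups, or whether any group here would give a lower number than hydrogen.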